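Trading a Cyclohexyl Ring for a Methyl Group

This account rests on a few compounds, and the source may have more. Where it says the series, first, only, none or still open, it means among the compounds named here.

Of the compounds shown here, two have been measured in a functional assay on M21 cells (Homo sapiens) for inhibition, read by sulforhodamine B assay, with a stated time of 48 h; a higher number here means a weaker inhibitor of growth, a lower number a stronger inhibitor of growth. Compound 1, with the structure `O=C(CCl)NC(=O)Nc1ccc(C2CCCCC2)cc1`, stands at the lowest of the two numbers: in this assay compound 1 gives 900 nM. Compound 2, with the structure `O=C(CCl)NC(=O)Nc1cccc(OCc2ccccc2)c1`, gives 4500 nM in this assay, a higher number that lies beyond the usual scatter, so compound 1 is the stronger inhibitor of growth of the pair. For the measured compounds named here, no step between two compounds differing in one place is available, so the size of any single change remains open.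

Compound 3, with the structure `Cc1ccc(NC(=O)NC(=O)CCl)cc1`, differs from compound 1 in one place: methyl in place of cyclohexyl on an aromatic carbon. Going by the values given here, because compound 1 is the only reference with a group on that aromatic carbon and gives 900 nM, the step to compound 3 is expected to be a move toward a higher number, of moderate size, with a fair chance it stays within the scatter. The estimated step from compound 1 to compound 3 is a 3.3-fold higher number from compound 1 to compound 3 (0.52 log units; beyond the scatter). Compound 3 is estimated at 3000 nM, in a range from 1000 nM to 10000 nM.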

Compound 3, concentration for 50% growth inhibition: 4900 nM
For compound 3 the middle estimate is 1.6-fold (0.21 log units) below the measured one, within the range that was stated.
By their numbers in this assay, from the lowest: compound 1; then compounds 2 and 3 (each within the scatter of the next).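

In this assay, for the compounds shown here, methyl in place of cyclohexyl on this aromatic carbon gives a 5.4-fold higher number from compound 1 to compound 3 (0.74 log units; beyond the scatter), the first step that changes only one place, and it shows that the group held here affects the growth-inhibition number. What leaves is a six-membered non-aromatic ring of 6 heavy atoms and what enters is a methyl of 1 heavy atom, while neither group has hydrogen-bond donors, hydrogen-bond acceptors or a net charge, so the counted difference between them lies in carbon atoms and the ring. Nothing at hand explains why the number moves with this change.

On these data alone, a single step cannot separate the loss of the ring from the loss of carbon atoms, so it remains open whether a longer chain such as n-hexyl on the same aromatic carbon would give a number closer to that of compound 1 or to that of compound 3. Also open, as far as these compounds go, is how groups of a different kind at this carbon, such as an amine or a carboxylic acid, would compare with methyl and cyclohexyl.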